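The source may hold more compounds than are shown below. What is called first, only, known or untested is meant among the compounds shown, and "the series" means these compounds.

Compound 1 `NC(=S)N1CCc2c(OCCCCCOc3ccc(Cl)cc3)cccc21` in an ADME assay on Huh-7 cells (Homo sapiens) for cytotoxicity (on this read-out higher numbers stand for lower toxicity in this test and lower numbers for higher toxicity in this test), gives > 50000 nM, which is a limit of the test rather than a number.
Compound 2 `O=C(NC(=S)N1CCc2c(OCCCCCOc3ccc(Cl)cc3)cccc21)c1ccc([N+](=O)[O-])cc1` gives 13600 nM.
Compound 3 `CN(C)c1ccc(C(=O)NC(=S)N2CCc3c(OCCCCCOc4ccc(Cl)cc4)cccc32)cc1` gives > 50000 nM, again a limit rather than a number.

As far as these compounds go, compound 3 therefore stands at the limit of > 50000 nM in this assay, at which 2 of the 3 values shown sit, so its exact value is unknown. Compound 4 `O=C(NC(=S)N1CCc2c(OCCCCCOc3ccc(Cl)cc3)cccc21)c1ccc2ccccc2c1` differs from it in one place: naphthalen-2-yl in place of 4-(dimethylamino)phenyl on a carbonyl carbon. Among the compounds with values here, no measured step makes exactly this change. The nearest are an at least 3.6-fold higher number from compound 2 to compound 3 (0.56 log units; beyond the scatter), where toxicity fell beyond the scatter, and an at least 3.6-fold lower number from compound 1 to compound 2 (0.56 log units; beyond the scatter), where it rose; the step that the two limits leave unreadable from compound 1 to compound 3 cannot be read. Swapping the aryl group has thus moved this read-out by modest amounts in both directions, and a modest shift toward compound 2 seems plausible for an aryl group lacking the dimethylamino. Compound 4 is expected to give 25000 nM, between 9000 nM and 60000 nM. This estimate implies an at least 2.0-fold lower number from compound 3 to compound 4 (0.30 log units; that floor lies within the scatter).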

Compound 4, half-maximal cytotoxic concentration: > 50000 nM
Compound 4 ended at the assay's limit (the forecaster's own chance of this, stated with the estimate: 40%); middle value at least 2.0-fold (0.30 log units) from the limit.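

In this assay, replacing the 4-nitrophenyl group on this carbonyl carbon with naphthalen-2-yl gives an at least 3.6-fold higher number from compound 2 to compound 4 (0.56 log units; beyond the scatter). Compound 4 ends at a limit of the test, so among the aryl groups shown, only the 4-nitrophenyl of compound 2 gives a measured number, and a second aryl group joins compound 3 at the limit. The steps from compound 3 to compound 4 and from compound 1 to compound 4 cannot be read, because both ends of each sit at a limit: the limit of > 50000 nM in this assay, at which 3 of the 4 values shown sit.

As far as these compounds go, it remains open whether other groups on the phenyl ring, such as a nitrile or a trifluoromethyl group, would also lower the number as the nitro group does. From the compounds shown here alone, the exact values of compound 3 and compound 4 also remain unknown.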